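A few compounds are considered here, and "the series" means these few. Any claim that something is new, unique, unknown or untested is made for them only; others in the source may bear on it.

Compound 1 `Nc1scc(CN2CCN(c3ccc([N+](=O)[O-])cc3)CC2)c1C(=O)c1ccc(Cl)cc1` is the starting point of this step. In a functional assay on CHO cells with adenosine receptor A1 (Homo sapiens) as the target, read by cAMP accumulation and immunoassay, with a stated time of 6 min, tested at 10 uM (a higher number here means a weaker effect of the compound at the concentration tested, a lower number a stronger effect), compound 1 gives -17%, the highest of the three numbers measured; compound 2 `Nc1scc(CN2CCN(c3ccc(F)c(Cl)c3)CC2)c1C(=O)c1ccc(Cl)cc1` gives -78% and compound 3 `Nc1scc(CN2CCN(CCCc3ccc(Cl)cc3)CC2)c1C(=O)c1ccc(Cl)cc1` gives -76%. The change to compound 4 `Nc1scc(CN2CCN(c3cc(Cl)ccc3Cl)CC2)c1C(=O)c1ccc(Cl)cc1` is 2,5-dichlorophenyl in place of 4-nitrophenyl on an amine nitrogen in a ring. Going by the values given here, two measured steps bear on it, both made at the same place: a number 61 percentage points lower from compound 1 to compound 2 (beyond the scatter) and a number 59 percentage points lower from compound 1 to compound 3 (beyond the scatter), while a number 2 percentage points higher from compound 2 to compound 3 (within the scatter). Since both replacements of the 4-nitrophenyl group gave large drops, a step of similar size is expected here, a number 53 percentage points lower from compound 1 to compound 4 (beyond the scatter). Compound 4 is therefore estimated at -70%, with an expected range from -90% to -40%.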

Compound 4, a percentage reported as activity, at one concentration (the size of the read-out at that concentration, not a potency): -62%
Estimate against measurement, compound 4: 8 percentage points below, and the stated range covers the measured number.
By their numbers in this assay, from the lowest: compounds 2 and 3 (each within the scatter of the next); then compound 4; then compound 1.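

In this assay, the 2,5-dichlorophenyl group gives a third large drop on the amine nitrogen in the ring (a number 45 percentage points lower from compound 1 to compound 4 (beyond the scatter)), so the fall from the 4-nitrophenyl compound is not confined to the first two replacements. The replacements are not equivalent, however (a number 16 percentage points higher from compound 2 to compound 4 (beyond the scatter); a number 14 percentage points higher from compound 3 to compound 4 (beyond the scatter)), a separation that compounds 2 and 3 alone did not show. No evidence here explains these differences. Going by these compounds, it remains open whether a plain phenyl, a 4-methoxyphenyl or a benzyl on this nitrogen would stand nearer compound 1 or compound 4.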